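This account rests on a few compounds, and the source may have more. Where it says the series, first, only, none or still open, it means among the compounds named here.

Working notes on the series. In an ADME assay on HeLa cells (Homo sapiens) for cytotoxicity, read by sulforhodamine B assay, with a stated time of 48 h, tested at 10 uM (on this read-out lower numbers stand for less inhibition and higher numbers for more inhibition at the one concentration tested (going by the name of the read-out)), compound 1 `CCCCCCc1cn(C(c2ccccc2)c2cc3cc(Br)ccc3nc2OC)nn1` gives -0.97%, compound 2 `CCOC(=O)c1cn(C(c2ccccc2)c2cc3cc(Br)ccc3nc2OC)nn1` gives -3.67%, and compound 3 `COc1nc2ccc(Br)cc2cc1C(c1ccccc1)n1cc(CCO)nn1` gives 0.85%. Compound 2 carries the lowest of the three numbers, but its nearest neighbour on the read-out is compound 1, with a number 2.7 percentage points lower from compound 1 to compound 2 (within the scatter), and its furthest is compound 3, with a number 4.5 percentage points higher from compound 2 to compound 3 (within the scatter); both steps are within the scatter, so the three compounds are not separated by this assay. The step from compound 1 to compound 3, a number 1.8 percentage points higher from compound 1 to compound 3 (within the scatter), is likewise within the scatter.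

Compound 4 `COc1nc2ccc(Br)cc2cc1C(c1ccccc1)n1cc(CCCCCO)nn1` is the next member to be measured. It differs from compound 2 in one place: 5-hydroxypentyl in place of ethoxycarbonyl on an aromatic carbon. Among the measured compounds shown here, the step that bears most directly on it is the one from compound 2 to compound 3, where the ethoxycarbonyl gave way to a hydroxyalkyl chain, and the step from compound 1 to compound 3, where chain length changed; neither moved the number beyond the scatter. For the measured compounds named here, no step in the set that swaps a group on this aromatic carbon has reached past the scatter, so for compound 4 the expected step in this assay is a number 3.7 percentage points higher from compound 2 to compound 4 (within the scatter), essentially none beyond the noise. The value estimated for compound 4 is 0%, in the range -8% to 8%.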

Compound 4, a percentage reported as inhibition, at one concentration (the size of the read-out at that concentration, not a potency): 1.08%
Estimate against measurement, compound 4: 1.1 percentage points below; the range from low to high includes it.
By their numbers in this assay, from the lowest: compounds 2, 1, 3 and 4 (each within the scatter of the next).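

In this assay, the exchange of ethoxycarbonyl for 5-hydroxypentyl, a group with a hydrogen-bond donor for one with none and a chain with no double bond outside aromatic rings, gives a number 4.8 percentage points higher from compound 2 to compound 4 (within the scatter), so this larger change at the aromatic carbon of the triazole-free description "five-membered aromatic ring with 3 nitrogen" still does not separate the two compounds. Extending the hydroxyalkyl chain gives a number 0.2 percentage points higher from compound 3 to compound 4 (within the scatter), and placing a terminal hydroxy on a chain of this length gives a number 2.1 percentage points higher from compound 1 to compound 4 (within the scatter), so neither chain length nor the terminal hydroxy separates the compounds here, and all four remain indistinguishable at this position. No measurement available here offers an explanation for these results.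

Still open, on these data alone, is whether any group at this position can move the number in this assay beyond the scatter, for example an amine, a carboxylic acid or a much longer chain. The compounds shown also leave open whether changing the bromo or phenyl substituents of the shared core would do so, and how any of these compounds would behave at other concentrations.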